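Swapping the halogenated phenyl on the shared core

The source may hold more compounds than are shown below. What is called first, only, known or untested is meant among the compounds shown, and "the series" means these compounds.

Of the compounds shown here, three on a common core have been measured in a functional assay on HeLa cells (Homo sapiens) for cytotoxicity, read by CCK-8 assay, with a stated time of 72 h; a lower number here means a stronger inhibitor, a higher number a weaker inhibitor. Compound 1 `C=CCn1c(=O)/c(=C\c2cc(F)ccc2C)[nH]c(=O)/c1=C\c1ccccc1OC` gives 2900 nM. Compound 2 `C=CCn1c(=O)/c(=C\c2ccccc2OC)[nH]c(=O)/c1=C\c1ccccc1OC` gives 6900 nM. Compound 3 `C=CCn1c(=O)/c(=C\c2cccc(Cl)c2Cl)[nH]c(=O)/c1=C\c1ccccc1OC` gives 1600 nM, the lowest of the three numbers, though its gap to compound 1 stays within the scatter, while its gap to compound 2 lies beyond it. The aryl swaps that were measured are a 2.4-fold higher number from compound 1 to compound 2 (0.38 log units; beyond the scatter), a 1.8-fold lower number from compound 1 to compound 3 (0.26 log units; within the scatter) and a 4.3-fold lower number from compound 2 to compound 3 (0.63 log units; beyond the scatter). The two halogenated phenyls, in compounds 1 and 3, sit close together; only the methoxyphenyl of compound 2 stands clearly apart.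

Compound 4 `C=CCn1c(=O)/c(=C\c2cc(Br)ccc2F)[nH]c(=O)/c1=C\c1ccccc1OC` has not yet been measured in this assay. It differs from compound 3 as follows: 5-bromo-2-fluorophenyl in place of 2,3-dichlorophenyl on a double-bonded chain carbon bound to an aromatic carbon. Since this exchanges one halogenated phenyl for another, the step from compound 1 to compound 3 is the closest guide, and that step was within the scatter. Compound 4 is therefore expected to fall near compound 3, with an expected step of a 1.4-fold higher number from compound 3 to compound 4 (0.14 log units; within the scatter), estimated at 2200 nM within a range of 1000 nM to 4800 nM.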

Compound 4, half-maximal inhibitory concentration: 34600 nM
The estimate for compound 4 lay 16-fold (1.20 log units) below the measured number; measured number outside the range, above it.
By their numbers in this assay, from the lowest: compounds 3 and 1 (each within the scatter of the next); then compound 2; then compound 4.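

Going by these compounds alone, until this result, the halogenated phenyls on the double-bonded chain carbon bound to an aromatic carbon had stayed close together, but in this assay the exchange for 5-bromo-2-fluorophenyl brings a 22-fold higher number from compound 3 to compound 4 (1.33 log units; beyond the scatter) and a 12-fold higher number from compound 1 to compound 4 (1.08 log units; beyond the scatter), so carrying halogens does not by itself keep the number low at this position. The number also rises beyond that of the 2-methoxyphenyl, with a 5.0-fold higher number from compound 2 to compound 4 (0.70 log units; beyond the scatter), which places the halogenated phenyls at both ends of the series and compound 2 inside them. The entering and leaving groups match in heavy-atom count and in hydrogen-bond donors and acceptors, and no measurement at hand accounts for the gap.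

From the compounds shown here alone, the halogens and their placement all change together in this step, and which of them carries it stays open. Also open, going by these compounds, is how a phenyl bearing bromine alone, fluorine alone or an amine would read at this position.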